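This account rests on a few compounds, and the source may have more. Where it says the series, first, only, none or still open, it means among the compounds named here.

Measured compounds and their values in an assay on isolated protein for inhibition of tissue alpha-L-fucosidase (Bos taurus), tested at 1000 uM; on this read-out lower numbers stand for less inhibition and higher numbers for more inhibition at the one concentration tested (going by the name of the read-out):
- compound 1, `OC[C@]1(c2cccc(F)c2)NC[C@H](O)[C@H]1O`: 0%
- compound 2, `COc1cccc([C@]2(CO)NC[C@@H](O)[C@@H]2O)c1`: 0%
- compound 3, `COc1cccc([C@@]2(CO)NC[C@H](O)[C@H]2O)c1`: 1.6%

All three compounds share one core, a saturated ring bearing a hydroxymethyl group, two hydroxyl groups and an aromatic ring. In this assay compound 3 holds the highest of the three numbers, but the gaps to compound 1 and to compound 2 are both within the scatter, so the three values cannot be told apart. Two measured steps lead to compound 3. One is a number 1.6 percentage points higher from compound 1 to compound 3 (within the scatter), the other is a number 1.6 percentage points higher from compound 2 to compound 3 (within the scatter); the second rests on (the fact that compounds 2 and 3 differ only in the configuration as drawn). Neither change moves the number beyond the scatter, and all three compounds sit close to no inhibition.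

Compound 4, `COc1ccc([C@@]2(CO)NC[C@H](O)[C@H]2O)cc1OC`, is not yet measured. It differs from compound 3 by methoxy in place of hydrogen on an aromatic carbon. Going by the values given here, the one aromatic change already measured, from compound 1 to compound 3, stayed within the scatter, and no compound here shows inhibition clearly above zero. A step of no size beyond the scatter is therefore expected in this assay, that is a number 0.4 percentage points higher from compound 3 to compound 4 (within the scatter). Compound 4 is estimated to give 2%, expected between 0% and 10%.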

Compound 4, a percentage reported as inhibition, at one concentration (the size of the read-out at that concentration, not a potency): 0.5%
For compound 4 the middle estimate is 1.5 percentage points above the measured one; low and high end bracket the measured number.
By their numbers in this assay, from the lowest: compounds 1, 2, 4 and 3 (each within the scatter of the next).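

In this assay, adding a methoxy group on the aromatic carbon ortho to a methoxy group and para to a group of 9 heavy atoms gives a number 1.1 percentage points lower from compound 3 to compound 4 (within the scatter). The earlier aromatic change swapped one group for another at a single place, whereas this one fills a further aromatic position, and the number still cannot be told apart from that of compound 3, so this position shows no measurable response to a methoxy group. No information given here bears on this step beyond the numbers themselves.

On these data alone, whether an amine or a carboxylic acid on this same aromatic carbon would lift the number clearly above zero remains open. Also open, as far as these compounds go, is whether any change at this position would matter on a core that shows clear inhibition in the first place.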